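Furan-2-yl Replaces a 2-(methylsulfanyl)ethyl Group

The source may hold more compounds than are shown below. What is called first, only, known or untested is meant among the compounds shown, and "the series" means these compounds.

In an ADME assay on Vero 76 cells (Chlorocebus sabaeus) for cytotoxicity, read by crystal violet staining, with a stated time of 96 h (a higher number here means that more compound is tolerated, a lower number that less compound is tolerated), compound 1 `Fc1ccc(NC(=S)Nc2cccc(C(F)(F)F)c2)cc1` gives 40000 nM. Compound 2 `C=C(C)CNC(=S)Nc1cccc(C(F)(F)F)c1` gives > 100000 nM, which is a limit of the assay. Compound 3 `CSCCCNC(=S)Nc1cccc(C(F)(F)F)c1` gives > 100000 nM, also a limit, so it stands at the limit of > 100000 nM in this assay, at which 2 of the 3 values shown sit. Compound 4 `FC(F)(F)c1cccc(NC(=S)NCc2ccco2)c1` carries furan-2-yl in place of 2-(methylsulfanyl)ethyl on a saturated chain carbon bound to an amide-type nitrogen. Going by the values given here, two measured steps bear on this by removing the aromatic 4-fluorophenyl of compound 1: an at least 2.5-fold higher number from compound 1 to compound 2 (0.39 log units; beyond the scatter) and an at least 2.5-fold higher number from compound 1 to compound 3 (0.39 log units; beyond the scatter). The third, a step that the two limits leave unreadable from compound 2 to compound 3, adds nothing. Since compound 4 regains an aromatic ring, a modest move toward a lower number is expected, with the estimated step of an at least 1.3-fold lower number from compound 3 to compound 4 (0.12 log units; that floor lies within the scatter). The estimate for compound 4 is 75000 nM, within an expected range of 30000 nM to 100000 nM.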

Compound 4, half-maximal cytotoxic concentration: 50000 nM
Beside the measured number, compound 4's estimate is 1.5-fold (0.18 log units) above it, and the stated range covers the measured number.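

In this assay, furan-2-yl on this saturated chain carbon gives a readable number, whereas the two open chains gave only a limit: the limit of > 100000 nM in this assay, at which 2 of the 4 values shown sit. The change brings an at least 2.0-fold lower number from compound 3 to compound 4 (0.30 log units; that floor lies within the scatter) and an at least 2.0-fold lower number from compound 2 to compound 4 (0.30 log units; that floor lies within the scatter), and the printed floors of both steps stay within the scatter. Against the aromatic group of compound 1, the result is a 1.3-fold higher number from compound 1 to compound 4 (0.10 log units; within the scatter), so (furan-2-yl)methyl and 4-fluorophenyl do not separate on the amide-type nitrogen. Still open, going by these compounds, is whether the saturated tetrahydrofuran-2-yl ring would return to the limit. Equally open, on these data alone, is how thiophen-2-yl or a chain amine would read here.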